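The compounds below may be only part of what the source reports. "The series", "measured", "known", "first", "only" and "open" are said of these compounds alone.

Working notes on the series. Compound 1 `S=C(Nc1ccccc1)N1N=C(c2ccc(Br)cc2)CC1c1ccc2c(c1)OCCO2` gives 870 nM in a functional assay on WM 266-4 cells (Homo sapiens) for antiproliferative activity, read by MTT assay, with a stated time of 48 h; a lower number here means a stronger inhibitor of growth, a higher number a weaker inhibitor of growth. For the measured compounds named here, compound 2 `CSc1ccc(C2=NN(C(=S)Nc3ccccc3)C(c3ccc4c(c3)OCCO4)C2)cc1` gives 197000 nM in this assay, the highest of the two numbers so far, and the one measured step, a 230-fold higher number from compound 1 to compound 2 (2.35 log units; beyond the scatter), is the whole of what is known about change at this aromatic carbon. Compound 3 `S=C(Nc1ccccc1)N1N=C(c2ccc(OCc3ccccc3)cc2)CC1c1ccc2c(c1)OCCO2` is the next member, still to be measured in this assay. It differs from compound 2 by benzyloxy in place of methylsulfanyl on an aromatic carbon. Going by the values given here, no measured step involves benzyloxy, so the only step that bears on compound 3 is a 230-fold higher number from compound 1 to compound 2 (2.35 log units; beyond the scatter), and that shows a change at this same carbon can move the number by a large amount. Its direction for benzyloxy cannot be read from a single step. A step beyond the scatter is expected for compound 3, most likely back toward a lower number. The number for compound 3 is therefore estimated at 40000 nM, with a range of 4000 nM to 400000 nM, which means an expected step of a 4.9-fold lower number from compound 2 to compound 3 (0.69 log units; beyond the scatter).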

Compound 3, concentration for 50% growth inhibition: 420 nM
Beside the measured number, compound 3's estimate is 95-fold (1.98 log units) above it; the measured number lies below the stated range.
By their numbers in this assay, from the lowest: compound 3; then compound 1; then compound 2.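

In this assay, the step of a 470-fold lower number from compound 2 to compound 3 (2.67 log units; beyond the scatter) shows that the loss seen with methylsulfanyl is not a general penalty for replacing bromo at this aromatic carbon, since a far larger group, benzyloxy, with its six-membered aromatic ring and 8 heavy atoms, is not only tolerated but gives the lowest number of the three. The further step of a 2.1-fold lower number from compound 1 to compound 3 (0.32 log units; beyond the scatter) is modest but beyond the scatter, so benzyloxy at least matches bromo here and goes slightly past it, while methylsulfanyl alone stands far from the other two, even though methylsulfanyl and benzyloxy have the same counts of hydrogen-bond donors and acceptors. Nothing available explains why these groups differ so sharply at this carbon.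

The compounds shown do not separate the contribution of the oxygen in benzyloxy from that of its aromatic ring; methoxy, phenyl or a longer chain such as butoxy at the same carbon would help to do so. From the compounds shown here alone, it also remains open whether an amine or a carboxylic acid would be tolerated here, and whether the methylsulfanyl result is particular to the sulfur, which an ethylsulfanyl or benzylsulfanyl group would test.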